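Swapping the dichloro ring for a trifluoromethyl ring

This account rests on a few compounds, and the source may have more. Where it says the series, first, only, none or still open, it means among the compounds named here.

Three compounds share a common core and differ only in the aryl group attached to the urea nitrogen. Compound 1 `COc1cc(Cl)cc(-c2nn(-c3cccc(NC(=O)Nc4ccc(Cl)c(C(F)(F)F)c4)c3)cc2-c2ccncc2)c1` gives -25% in a functional assay on SNB-19 cells (Homo sapiens) for inhibition, read by sulforhodamine B assay, with a stated time of 48 h, tested at 100 uM (a higher number here means a weaker effect of the compound at the concentration tested, a lower number a stronger effect), compound 2 `COc1cc(Cl)cc(-c2nn(-c3cccc(NC(=O)Nc4cc(C(F)(F)F)cc(C(F)(F)F)c4)c3)cc2-c2ccncc2)c1` gives -42%, and compound 3 `COc1cc(Cl)cc(-c2nn(-c3cccc(NC(=O)Nc4ccc(Cl)c(Cl)c4)c3)cc2-c2ccncc2)c1` gives 10%. Compound 3 therefore stands highest of the three, its nearest neighbour being compound 1 and its furthest compound 2, both beyond the scatter.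

Compound 4 `COc1cc(Cl)cc(-c2nn(-c3cccc(NC(=O)Nc4cccc(C(F)(F)F)c4)c3)cc2-c2ccncc2)c1` has not yet been measured. It differs from compound 3 by 3-(trifluoromethyl)phenyl in place of 3,4-dichlorophenyl on an amide-type nitrogen. Going by the values given here, the one measured step that bears on this is a number 35 percentage points higher from compound 1 to compound 3 (beyond the scatter), where chloro in place of trifluoromethyl raised the number and so weakened the effect. Among the compounds with values here, compound 4 reverses that exchange while also removing a chloro, so a sizeable step downward toward a stronger effect is expected, roughly of the order seen from compound 1 to compound 3, although no measured pair matches the change exactly.

For compound 4 a value of -15% is estimated, within a range from -45% to 15%, meaning an expected step of a number 25 percentage points lower from compound 3 to compound 4 (beyond the scatter).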

Compound 4, a percentage reported as activity, at one concentration (the size of the read-out at that concentration, not a potency): -13%
Estimate against measurement, compound 4: 2 percentage points below; measured number inside the range.
By their numbers in this assay, from the lowest: compound 2; then compound 1; then compound 4; then compound 3.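

In this assay, the step of a number 23 percentage points lower from compound 3 to compound 4 (beyond the scatter) shows that a lone trifluoromethyl on the ring, with no chloro present, still gives a stronger effect than 3,4-dichlorophenyl. The second group on the trifluoromethyl ring also matters: losing the chloro gives a number 12 percentage points higher from compound 1 to compound 4 (beyond the scatter) and losing the second trifluoromethyl gives a number 29 percentage points higher from compound 2 to compound 4 (beyond the scatter), so 3-(trifluoromethyl)phenyl gives a weaker effect than either of these two more heavily substituted rings. Nothing measured here explains why these exchanges shift the number.

The compounds shown leave open how a ring carrying a single chloro, or no group at all, would compare, which would separate the contribution of chloro from that of trifluoromethyl. They also leave open whether a nitrile or an amine in place of trifluoromethyl would keep the effect.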